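This account rests on a few compounds, and the source may have more. Where it says the series, first, only, none or still open, it means among the compounds named here.

Working notes on the series. Compound 1 `CSc1nnc(C)n1N1C(=O)c2ccccc2C1=O` opens it. In a functional assay on PC-3M cells (Homo sapiens) for cytotoxicity, read by MTT assay, with a stated time of 48 h (a higher number here means a weaker inhibitor, a lower number a stronger inhibitor), compound 1 gives only a limit, > 200000 nM. Compound 2 `C#CCSc1nnc(CC)n1N1C(=O)c2ccccc2C1=O` in this assay also gives only a limit, > 200000 nM. For the measured compounds named here, compound 2 thus stands at the limit of > 200000 nM in this assay, at which 2 of the 2 values shown sit, so no step between measured compounds can be drawn.

Compound 3 `CCc1nnc(SCC(=O)c2ccc(C)cc2)n1N1C(=O)c2ccccc2C1=O` differs from compound 2 by (4-methylphenyl)carbonyl in place of ethynyl on a saturated chain carbon bound to a sulfur. With both measured values sitting at a limit, no direction can be read from them; the expected step in this assay is an at least 1.3-fold lower number from compound 2 to compound 3 (0.12 log units; that floor lies within the scatter), nothing beyond the scatter. Compound 3 is accordingly estimated at 150000 nM, within 30000 nM to 600000 nM, most likely reported again as a limit.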

Compound 3, half-maximal inhibitory concentration: > 200000 nM
Compound 3 was reported as a limit; the forecaster's own chance of this, stated with the estimate: 70%; middle value at least 1.3-fold (0.12 log units) away from the limit.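

For the compounds shown here, compound 2 and compound 3 both sit at a limit, so no step between them can be read: the limit of > 200000 nM in this assay, at which 3 of the 3 values shown sit. The compounds shown leave open what numerical potency, if any, this series reaches in this assay.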